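From a Six-Membered Ring to a Five-Membered One

This account rests on a few compounds, and the source may have more. Where it says the series, first, only, none or still open, it means among the compounds named here.

Of the compounds shown here, three sharing one core have been measured so far in a physicochemical assay for solubility, read by spectrophotometry, measured as kinetic solubility, at pH 8, tested at 500 uM; a higher number here means a more soluble compound, a lower number a less soluble compound. Compound 1 `Cn1cc(NC(=O)c2ccncc2Nc2cc(-c3ccc4ccn(C)c4c3)c3nccnc3c2)cn1` gives 2 ug/mL, compound 2 `CN1CCC(NC(=O)c2ccncc2Nc2cc(-c3ccc4ccn(C)c4c3)c3nccnc3c2)CC1=O` gives 48 ug/mL, and compound 3 `CN1CC(NC(=O)c2ccncc2Nc2cc(-c3ccc4ccn(C)c4c3)c3nccnc3c2)CCC1=O` gives 253 ug/mL. Compound 3 is therefore the highest of the three, clearly ahead of both others.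

The next compound, compound 4 `CC(=O)N1CCC(NC(=O)c2ccncc2Nc2cc(-c3ccc4ccn(C)c4c3)c3nccnc3c2)C1`, keeps the core and alters only the group on the amide-type nitrogen: 1-acetylpyrrolidin-3-yl in place of 1-methyl-6-oxopiperidin-3-yl on an amide-type nitrogen. The two compounds have the same atoms, joined differently.

Two measured steps replaced the 1-methyl-1H-pyrazol-4-yl group, and both were large: a 24-fold higher number from compound 1 to compound 2 (1.38 log units; beyond the scatter) and a 130-fold higher number from compound 1 to compound 3 (2.10 log units; beyond the scatter). Neither resembles the present change, as that group plays no part in it. The closer guide is the modest step of a 5.3-fold higher number from compound 2 to compound 3 (0.72 log units; beyond the scatter), between the 1-methyl-2-oxopiperidin-4-yl and 1-methyl-6-oxopiperidin-3-yl groups. It shows that exchanging one such group for the other moved the number beyond the scatter.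

For the measured compounds named here, no measured compound carries 1-acetylpyrrolidin-3-yl, so the direction is uncertain. With compound 3 at the top of the series at 253 ug/mL, a fall seems more likely than a rise. The expected change is a modest fall, a 2.1-fold lower number from compound 3 to compound 4 (0.32 log units; beyond the scatter). For compound 4 the estimate is 120 ug/mL, with an expected range of 40 ug/mL to 280 ug/mL.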

Compound 4, solubility: 253 ug/mL
Estimate against measurement, compound 4: 2.1-fold (0.32 log units) below; the measured number falls inside the stated range.
By their numbers in this assay, from the lowest: compound 1; then compound 2; then compounds 3 and 4 (each within the scatter of the next).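

Changing the group on the amide-type nitrogen from a six-membered to a five-membered non-aromatic ring, with the same atoms and the same counts of hydrogen-bond donors and acceptors, gave in this assay no change at the digits printed from compound 3 to compound 4 (within the scatter). Rearranging these atoms therefore need not move the number, although the exchange of 1-methyl-2-oxopiperidin-4-yl for 1-methyl-6-oxopiperidin-3-yl did, with a 5.3-fold higher number from compound 2 to compound 3 (0.72 log units; beyond the scatter), and 1-acetylpyrrolidin-3-yl keeps the same lead over the other two groups, with a 5.3-fold higher number from compound 2 to compound 4 (0.72 log units; beyond the scatter) and a 130-fold higher number from compound 1 to compound 4 (2.10 log units; beyond the scatter). Nothing offered here explains why these two groups read alike.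

As far as these compounds go, what remains open is whether the acetyl group matters at all at this position, since a pyrrolidine with a free ring amine or a 1-methylpyrrolidin-3-yl group would test that directly. From the compounds shown here alone, it is also open whether the number would hold with a four-membered azetidine ring carrying the same acetyl group, or with an open chain ending in an acetyl amide in place of the ring.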